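A few compounds are considered here, and "the series" means these few. Any claim that something is new, unique, unknown or untested is made for them only; others in the source may bear on it.

Measured so far in a functional assay on HeLa cells (Homo sapiens) for cytotoxicity, read by MTT assay, with a stated time of 72 h, tested at 30 uM; on this read-out higher numbers stand for more inhibition of growth at the one concentration tested and lower numbers for less inhibition of growth:
compound 1 `N/C(=N\NC(=S)N1CCOCC1)c1ccccn1` gives 82.8%
compound 2 `Cc1ccnc(/C(N)=N/NC(=S)N2CCOCC2)c1` gives 45.2%

Compound 2 holds the lower of these two numbers. For the measured compounds named here, the single measured step, a number 37.6 percentage points lower from compound 1 to compound 2 (beyond the scatter), concerns a methyl placed on an aromatic carbon and separates compound 2 from compound 1. Compound 3 `Cc1ccnc(/C(N)=N/NC(=S)N2CCSCC2)c1` differs from compound 2 by thiomorpholin-4-yl in place of morpholin-4-yl on a thiocarbonyl carbon. No measured step touches such an exchange at the thiocarbonyl carbon, so nothing shown points to a direction or size. The expected step is a number 0.2 percentage points lower from compound 2 to compound 3 (within the scatter), within the scatter. Compound 3 is therefore estimated at 45%, with a range from 20% to 70%.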

Compound 3, percent growth inhibition at one concentration: 78.3%
Compound 3: middle estimate off by 33.3 percentage points, on the low side; measured number above the stated range.
By their numbers in this assay, from the lowest: compound 2; then compounds 3 and 1 (each within the scatter of the next).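

In this assay, for the compounds shown here, the thiocarbonyl carbon proves to be a sensitive place, with the exchange of morpholin-4-yl for thiomorpholin-4-yl giving a number 33.1 percentage points higher from compound 2 to compound 3 (beyond the scatter) even though only one ring atom differs, sulfur for oxygen. Going by these compounds alone, the earlier step concerned the methyl on an aromatic carbon, so this is the first sign that the ring on the thiocarbonyl carbon also matters. Nothing available explains this step. Going by these compounds, it remains open whether the same exchange acts alike without the methyl, on the core of compound 1. On these data alone, how a piperidin-1-yl or piperazin-1-yl ring would behave at the thiocarbonyl carbon also remains open.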